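Fluoro for Cyano Across Two Cores

The source may hold more compounds than are shown below. What is called first, only, known or untested is meant among the compounds shown, and "the series" means these compounds.

Of the compounds shown here, three have been measured in an ADME assay on MDCK cells (Canis lupus familiaris) for cytotoxicity, read by MTT assay, with a stated time of 24 h; a lower number here means that less compound is tolerated, a higher number that more compound is tolerated. Compound 1 `Cc1cc(CNS(=O)(=O)c2ccc(C#N)cc2)c(C)o1` gives 105000 nM in this assay, and compound 2 `Cc1cc(CNS(=O)(=O)c2ccc(F)cc2)c(C)o1` gives 138000 nM. These two differ in a single place: fluoro in place of cyano on an aromatic carbon. That change made a 1.3-fold higher number from compound 1 to compound 2 (0.12 log units; within the scatter). Compound 3 `N#Cc1ccc(S(=O)(=O)NCc2csc3ccccc23)cc1` rests on a different core, and how its core differs from that of compound 1 is not broken down here. In this assay compound 3 gives 122000 nM, a number that sits within the scatter of both compound 1 and compound 2, so no order among the three can be read from these values.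

Compound 4 `O=S(=O)(NCc1csc2ccccc12)c1ccc(F)cc1` has not yet been measured. It stands to compound 3 as compound 2 stands to compound 1: fluoro in place of cyano on an aromatic carbon. The place is described in the same words for both pairs, so this is the same change carried onto the core of compound 3. For the measured compounds named here, only one measured instance of the change exists, and it stayed within the scatter.

Compound 4 is therefore expected to give about 150000 nM in this assay, with a likely range from 90000 nM to 260000 nM. The estimated step of a 1.2-fold higher number from compound 3 to compound 4 (0.09 log units; within the scatter) rests on that single measured instance, because it produced a 1.3-fold higher number from compound 1 to compound 2 (0.12 log units; within the scatter). Whether the second core behaves the same way cannot be known until compound 4 is measured.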

Compound 4, half-maximal cytotoxic concentration: 98600 nM
Compound 4: the middle estimate sits 1.5-fold (0.18 log units) above what was measured, within the range that was stated.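

In this assay, fluoro in place of cyano on an aromatic carbon of the core of compound 3 gave a 1.2-fold lower number from compound 3 to compound 4 (0.09 log units; within the scatter), and set beside the earlier instance of the same change, this step does not differ from it by more than repeated measurement would allow: the same change on two cores in this assay, a 1.3-fold higher number (0.12 log units; within the scatter) from compound 1 to compound 2 and a 1.2-fold lower number (0.09 log units; within the scatter) from compound 3 to compound 4, 1.6-fold (0.21 log units) apart, within the scatter of two such steps. This shows that, on these two cores, the exchange leaves the number within the scatter, and that neither core gives a reason to treat it differently from the other. For the compounds shown here, it does not show that the exchange is without effect in general, since it rests on only two pairs of compounds, and the opposite directions of the two printed steps cannot be read as a reversal between the cores.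

The compounds shown leave open whether the same exchange would stay within the scatter on a third core, since the two cores here are all that can be compared. They also leave open whether a different group on that same aromatic carbon, para to a large group, such as an amine or a carboxylic acid, would move the number in this assay beyond the scatter.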